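The source may hold more compounds than are shown below. What is called first, only, known or untested is meant among the compounds shown, and "the series" means these compounds.

Measured compounds in a physicochemical assay for lipophilicity, at pH 7.4; a higher number here means a more lipophilic compound, a lower number a more polar compound:
Compound 1, `Cc1ccc2c(NCc3ccco3)nc(NC(C)C)nc2c1`, gives 3.61.
Compound 2, `Cc1ccc2nc(NC(C)C)nc(NCc3ccco3)c2c1`, gives 3.63.
Compound 3, `COc1ccc2c(NCc3ccco3)nc(NC(C)C)nc2c1`, gives 3.7.

Compound 3 differs from compound 1 by methoxy in place of methyl on an aromatic carbon, and in this assay that change made a step of a number 0.09 log units higher from compound 1 to compound 3 (within the scatter). Compound 2 has the same atoms as compound 1 joined differently; the difference between the two cores is not broken down here, and the two values of compounds 1 and 2 lie within the scatter of each other, as do those of compounds 2 and 3. Compound 4, `COc1ccc2nc(NC(C)C)nc(NCc3ccco3)c2c1`, has not yet been measured; it differs from compound 2 by methoxy in place of methyl on an aromatic carbon, the same change that leads from compound 1 to compound 3. Because that earlier step was a number 0.09 log units higher from compound 1 to compound 3 (within the scatter), the step from compound 2 to compound 4 in this assay is expected to be a number 0.09 log units higher from compound 2 to compound 4 (within the scatter). Compound 4 is therefore estimated at 3.72, between 3.4 and 4.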

Compound 4, distribution coefficient: 3.58
Compound 4: the middle estimate sits 0.14 log units above what was measured, within the range that was stated.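

In this assay, methoxy in place of methyl on an aromatic carbon gave a step of a number 0.05 log units lower from compound 2 to compound 4 (within the scatter) on one core, against a number 0.09 log units higher from compound 1 to compound 3 (within the scatter) on the other. Both steps lie within the scatter, so the swap carries across these two cores only in the sense that neither pair shows a step that can be told from repeat measurement, and the differing signs do not show that the cores respond differently. Nothing shown here offers an explanation for either step, and one pair per core cannot establish a rule for the series.

The compounds shown hold only methyl and methoxy at this place. Going by these compounds, whether an ethoxy group, an amine or a carboxylic acid there would give a step beyond the scatter, and would give the same step on both cores, remains open.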